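Dropping the Methoxy from the Benzamide of Compound 2

The source may report more compounds than this note shows. Statements on the series, on what has been measured and on what is new or still open speak of the compounds shown alone.

The three measured compounds share one core. Compound 1 `O=C(CSc1nc2ccc(NC(=O)c3ccc([N+](=O)[O-])cc3)cc2s1)NCc1ccccc1` is known only as a limit in a functional assay on HepG2 cells (Homo sapiens) for cytotoxicity, read by MTT assay, with a stated time of 48 h (a lower number here means a stronger inhibitor, a higher number a weaker inhibitor), where compound 1 gives > 100000 nM (the limit of > 100000 nM in this assay, at which 1 of the 3 values shown sits). Compound 3 `CC(=O)Nc1ccc2nc(SCC(=O)NCc3ccccc3)sc2c1` gives 9200 nM in this assay, a change read as an at least 10-fold lower number from compound 1 to compound 3 (1.03 log units; beyond the scatter). Compound 2 `COc1ccc(CNC(=O)CSc2nc3ccc(NC(=O)c4ccccc4OC)cc3s2)cc1` gives 2100 nM in this assay, the lowest of the two numbers, its nearest neighbour being compound 3.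

Compound 4 `COc1ccc(CNC(=O)CSc2nc3ccc(NC(=O)c4ccccc4)cc3s2)cc1` differs from compound 2 by hydrogen in place of methoxy on an aromatic carbon. Among the compounds with values here, no measured step matches this change: the only step recorded alters what sits on the carbonyl carbon, not a substituent on the phenyl ring, so it says little about removing a methoxy there. Within the data shown here, with no precedent for this edit, the step expected for this assay is small, none beyond the scatter, leaning if anywhere toward a slightly higher number, so that the estimated change is a 1.4-fold higher number from compound 2 to compound 4 (0.15 log units; within the scatter). Compound 4 is therefore expected to give about 3000 nM in this assay, within a range of 1000 nM to 10000 nM.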

Compound 4, half-maximal inhibitory concentration: 12700 nM
The estimate for compound 4 lay 4.2-fold (0.63 log units) below the measured number; the whole stated range lies below it.
By their numbers in this assay, from the lowest: compound 2; then compounds 3 and 4 (each within the scatter of the next). At a limit, above all of these: compound 1.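

Removing this methoxy is not a neutral edit: in this assay the change gives a 6.0-fold higher number from compound 2 to compound 4 (0.78 log units; beyond the scatter), while the second methoxy of compound 2 stays in compound 4, so the step belongs to the ring of the benzamide alone. Within the data shown here, the one earlier step replaced the whole group on the carbonyl carbon, whereas this one shows that a single substituent ortho to a large group on that ring can by itself shift the number beyond the scatter. The evidence at hand does not bear on this step, so the shift stays without an explanation.

The compounds shown leave open whether methoxy is special at this carbon or whether a hydroxyl, a fluorine or an ethoxy there would serve as well. They also leave open how a methoxy would read on another carbon of the same ring.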